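Series notes: acyl variation on the aromatic nitrogen

The source may hold more compounds than are shown below. What is called first, only, known or untested is meant among the compounds shown, and "the series" means these compounds.

Among the measured compounds shown here, compound 2 `COC(=O)C(=O)Nc1cccc(C(=O)/C=C/c2ccc(O)c(OC)c2)c1` gives the lowest of the three numbers so far in a functional assay on Vero cells (Chlorocebus sabaeus) for inhibition (a lower number here means a stronger inhibitor, a higher number a weaker inhibitor), with 3.55 ug/mL. Compound 1 `COc1cc(/C=C/C(=O)c2cccc(N)c2)ccc1O` gives 6.02 ug/mL, and the step of a 1.7-fold lower number from compound 1 to compound 2 (0.23 log units; within the scatter) lies within the scatter. Compound 3 `COc1cc(/C=C/C(=O)c2cccc(NC(C)=O)c2)ccc1O` gives 14.5 ug/mL; the steps of a 2.4-fold higher number from compound 1 to compound 3 (0.38 log units; beyond the scatter) and a 4.1-fold higher number from compound 2 to compound 3 (0.61 log units; beyond the scatter) lie beyond it. Compound 4 `COc1cc(/C=C/C(=O)c2cccc(NC(=O)c3ccc(Cl)cc3)c2)ccc1O` differs from compound 2 as follows: 4-chlorophenyl in place of methoxycarbonyl on a carbonyl carbon. For the measured compounds named here, the only measured step at the same carbonyl carbon, a 4.1-fold higher number from compound 2 to compound 3 (0.61 log units; beyond the scatter), raised the number modestly when methyl replaced methoxycarbonyl; no measured step brings an aromatic ring into that place, so the direction for 4-chlorophenyl is not settled by the data. A small to modest rise in this assay is expected, a 1.8-fold higher number from compound 2 to compound 4 (0.26 log units; within the scatter). Compound 4 is estimated at 6.5 ug/mL, within 2.5 ug/mL to 17 ug/mL.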

Compound 4, half-maximal inhibitory concentration: 3.82 ug/mL
Estimate against measurement, compound 4: 1.7-fold (0.23 log units) above; the measured number falls inside the stated range.
By their numbers in this assay, from the lowest: compounds 2, 4 and 1 (each within the scatter of the next); then compound 3.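

In this assay the carbonyl carbon accepts an aromatic ring: a 1.1-fold higher number from compound 2 to compound 4 (0.03 log units; within the scatter) leaves 4-chlorophenyl not distinguishable from methoxycarbonyl, whereas a 3.8-fold lower number from compound 3 to compound 4 (0.58 log units; beyond the scatter) sets it clear of methyl. Against the free amine, a 1.6-fold lower number from compound 1 to compound 4 (0.20 log units; within the scatter) stays inside the scatter, so the rise seen with acetyl does not extend to every acyl group, and compound 3 alone stands apart among the four.

Whether the chlorine contributes is open, as the compounds include no unsubstituted phenyl at this carbon. Also open, on these data alone, are an amine, a carboxylic acid or a longer alkyl chain in that place. No supporting data bear on the reason for these differences.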